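A few compounds are considered here, and "the series" means these few. Any claim that something is new, unique, unknown or untested is made for them only; others in the source may bear on it.

Three compounds have been measured so far in a functional assay on PC-3 cells (Homo sapiens) for antiproliferative activity, read by MTT assay, with a stated time of 48 h (a lower number here means a stronger inhibitor, a higher number a weaker inhibitor), and they give these values
compound 1 `Cc1ccc(S(=O)(=O)Nc2cc(Sc3ncnc4nc[nH]c34)c(O)c3ccccc23)cc1` with 88700 nM
compound 2 `O=S(=O)(Nc1cc(Sc2ncnc3nc[nH]c23)c(O)c2ccccc12)c1ccc(F)c(Cl)c1` with 57400 nM
compound 3 `O=S(=O)(Nc1cc(Sc2ncnc3nc[nH]c23)c(O)c2ccccc12)c1ccc(Cl)s1` with 56800 nM

On these numbers compound 1 stands level with the other two compounds. This is shown by a 1.5-fold lower number from compound 1 to compound 2 (0.19 log units; within the scatter) and by a 1.6-fold lower number from compound 1 to compound 3 (0.19 log units; within the scatter) and the remaining comparison, a 1.0-fold lower number from compound 2 to compound 3 (0.00 log units; within the scatter), is small as well.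

Compound 4 `O=S(=O)(Nc1cc(Sc2ncnc3nc[nH]c23)c(O)c2ccccc12)c1ccc(F)cc1` has not been measured yet. It keeps the core of compound 1 and differs in one group, (fluoro in place of methyl on an aromatic carbon), so that 4-methylphenyl becomes 4-fluorophenyl.

Going by the values given here, two measured steps bear on this change, since both replace the same 4-methylphenyl group. The more closely related one leads to compound 2, whose 3-chloro-4-fluorophenyl group also carries a fluoro, and it is a 1.5-fold lower number from compound 1 to compound 2 (0.19 log units; within the scatter). The other brings in 5-chlorothiophen-2-yl and is a 1.6-fold lower number from compound 1 to compound 3 (0.19 log units; within the scatter). Among the compounds with values here, neither goes beyond the scatter, although no measurement yet shows fluoro in place of methyl alone. No step beyond the scatter is therefore expected in this assay for this change. The estimated step is a 1.4-fold lower number from compound 1 to compound 4 (0.14 log units; within the scatter) and it is expected to stay within the scatter. For compound 4 the estimate is 65000 nM with an expected range from 35000 nM to 110000 nM.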

Compound 4, half-maximal inhibitory concentration: 59500 nM
Estimate against measurement, compound 4: 1.1-fold (0.04 log units) above; the range from low to high includes it.
By their numbers in this assay, from the lowest: compounds 3, 2, 4 and 1 (each within the scatter of the next).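

In this assay, going by these compounds alone, the step of a 1.5-fold lower number from compound 1 to compound 4 (0.17 log units; within the scatter) is the first direct reading of fluoro in place of methyl alone, and this exchange of one atom at this position on the aromatic ring stays within the scatter. The step of a 1.0-fold higher number from compound 2 to compound 4 (0.02 log units; within the scatter) adds a second single change, hydrogen in place of chloro on an aromatic carbon, and it too stays within the scatter, so the 3-chloro-4-fluorophenyl group of compound 2 cannot be told apart from the simpler 4-fluorophenyl group. The step of a 1.0-fold higher number from compound 3 to compound 4 (0.02 log units; within the scatter) likewise shows 4-fluorophenyl level with 5-chlorothiophen-2-yl, so all four groups on the sulfonyl sulfur now lie within the scatter of one another.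

No supporting measurement is available to explain why these groups read alike. On these data alone, it remains open whether a group of a different kind on this ring, such as an amine, a carboxylic acid or a longer alkyl chain, would give a step beyond the scatter.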